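The source may hold more compounds than are shown below. What is called first, only, known or untested is meant among the compounds shown, and "the series" means these compounds.

Measured in an ADME assay on CCRF-CEM cells (Homo sapiens), read by XTT assay, with a stated time of 72 h; on this read-out lower numbers stand for stronger inhibition and higher numbers for weaker inhibition:
Compound 1 `O=C1C=CC(=O)C1=Cc1ccccc1`: 2600 nM
Compound 2 `COc1ccc(C=C2C(=O)C=CC2=O)cc1`: 3800 nM
Compound 3 `Cc1ccc(C=C2C(=O)C=CC2=O)cc1`: 2700 nM

In this assay compound 3 gives 2700 nM, which lies within the scatter of both other compounds. Compound 4 `O=C1C=CC(=O)C1=Cc1ccc(Cl)cc1` differs from it by one swap: chloro in place of methyl on an aromatic carbon. Among the compounds with values here, no measured step involves chloro, so only neighbouring changes can guide the expectation. Methyl in place of hydrogen gave a 1.0-fold higher number from compound 1 to compound 3 (0.02 log units; within the scatter). Methoxy in place of hydrogen gave a 1.5-fold higher number from compound 1 to compound 2 (0.16 log units; within the scatter). Methyl in place of methoxy gave a 1.4-fold lower number from compound 2 to compound 3 (0.15 log units; within the scatter). None of these steps leaves the scatter, so no real shift is expected in either direction. The expected step is a 1.1-fold lower number from compound 3 to compound 4 (0.03 log units; within the scatter). Compound 4 is estimated at 2500 nM, with an expected range of 1200 nM to 5000 nM.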

Compound 4, half-maximal inhibitory concentration: 6100 nM
Compound 4: middle estimate off by 2.4-fold (0.39 log units), on the low side; measured number outside the range, above it.
By their numbers in this assay, from the lowest: compounds 1, 3, 2 and 4 (each within the scatter of the next, the first and the last beyond it).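

In this assay, within the data shown here, chloro is the first change at this position on the aromatic ring to leave the scatter, with a 2.3-fold higher number from compound 1 to compound 4 (0.37 log units; beyond the scatter) and a 2.3-fold higher number from compound 3 to compound 4 (0.35 log units; beyond the scatter) while a 1.6-fold higher number from compound 2 to compound 4 (0.21 log units; within the scatter) stays within it. The position is therefore not indifferent to its group: chloro inhibits more weakly than hydrogen or methyl, though compound 2 with methoxy goes against a clear separation. Nothing shown here gives a cause for this shift. On these data alone, it remains open whether an amine or a carboxylic acid at this position would move the number as chloro does, and whether chloro elsewhere on the ring would behave alike.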